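This account rests on a few compounds, and the source may have more. Where it says the series, first, only, none or still open, it means among the compounds named here.

Measured compounds:
compound 1, `OC[C@H]1O[C@@H](n2cnc3c(NCc4ccccc4Br)ncnc32)[C@H](O)[C@@H]1O`, > 166000 nM
compound 2, `OC[C@H]1O[C@@H](n2cnc3c(NCc4ccc(Br)cc4)ncnc32)[C@H](O)[C@@H]1O`, > 166000 nM
compound 3, `COc1cccc(CNc2ncnc3c2ncn3[C@@H]2O[C@H](CO)[C@@H](O)[C@H]2O)c1`, "not determined" (no result reported)

In a functional assay on G-361 cells (Homo sapiens) for antiproliferative activity, with a stated time of 72 h (a lower number here means a stronger inhibitor, a higher number a weaker inhibitor), compound 1 gives > 166000 nM, which is a limit of the assay and not a number. Compound 2 likewise gives > 166000 nM, again a limit. For compound 3 this assay reports "not determined" (no result reported). The one change among these compounds, a step that the two limits leave unreadable from compound 1 to compound 2, therefore cannot be sized. Compound 1 thus stands only at a limit, with no measured value to place it against.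

Compound 4, `OC[C@H]1O[C@@H](n2cnc3c(NCc4ccccc4OC(F)F)ncnc32)[C@H](O)[C@@H]1O`, differs from compound 1 by difluoromethoxy in place of bromo on an aromatic carbon; read one bond further out, 2-bromophenyl becomes 2-(difluoromethoxy)phenyl. For the measured compounds named here, no measured step bears on this change. What the data offer is the limit of > 166000 nM in this assay, at which 2 of the 3 values shown sit, so compound 4 is expected to sit near that limit as well. The step is expected to be a step that the limit leaves unreadable from compound 1 to compound 4, which is no more than the scatter allows. Compound 4 is estimated at 200000 nM, within a range from 50000 nM to 1000000 nM.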

Compound 4, half-maximal inhibitory concentration: > 166000 nM
Compound 4 was reported as a limit; the forecaster's own chance of this, stated with the estimate: 80%; the middle value does not contradict the limit.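

In this assay, for the compounds shown here, compound 4 gives > 166000 nM, a limit and not a number, so no step to it from compound 1 or compound 2 can be read. The compounds shown leave open whether any change on the aromatic ring alters the antiproliferative activity at all: the limit of > 166000 nM in this assay, at which 3 of the 4 values shown sit.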